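The compounds below may be only part of what the source reports. "The series", "measured", "known", "first", "only" and "open" are said of these compounds alone.

In a functional assay on CHO cells with adenosine receptor A1 (Homo sapiens) as the target, read by cAMP accumulation and immunoassay, with a stated time of 6 min, tested at 10 uM (on this read-out lower numbers stand for a stronger effect and higher numbers for a weaker effect at the one concentration tested), the three measured compounds gave these numbers:
compound 1 `Nc1scc(CN2CCN(c3ccc(Cl)cc3Cl)CC2)c1C(=O)c1ccc(Cl)cc1`: -74%
compound 2 `Nc1scc(CN2CCN(c3cc(Cl)cc(Cl)c3)CC2)c1C(=O)c1ccc(Cl)cc1`: -74%
compound 3 `Nc1scc(CN2CCN(c3ccc(F)cc3Cl)CC2)c1C(=O)c1ccc(Cl)cc1`: -70%

Compound 3 holds the highest of the three numbers, yet the step of a number 4 percentage points higher from compound 1 to compound 3 (within the scatter) and the step of a number 4 percentage points higher from compound 2 to compound 3 (within the scatter) both lie within the scatter, as does no change at the digits printed from compound 1 to compound 2 (within the scatter). Compound 4 `COc1ccc(N2CCN(Cc3csc(N)c3C(=O)c3ccc(Cl)cc3)CC2)cc1` differs from compound 3 by 4-methoxyphenyl in place of 2-chloro-4-fluorophenyl on an amine nitrogen in a ring. For the measured compounds named here, all three measured steps swap one halogen-bearing ring for another on the same ring nitrogen and none moved the read-out beyond the scatter; no measured step introduces a methoxy group. Compound 4 is therefore expected to show a step of a number 5 percentage points higher from compound 3 to compound 4 (within the scatter), with a value estimated at -65% (range -85% to -40%).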

Compound 4, a percentage reported as activity, at one concentration (the size of the read-out at that concentration, not a potency): -52%
The estimate for compound 4 lay 13 percentage points below the measured number; low and high end bracket the measured number.
By their numbers in this assay, from the lowest: compounds 1, 2 and 3 (each within the scatter of the next); then compound 4.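

In this assay, for the compounds shown here, 4-methoxyphenyl on the amine nitrogen in a ring is the first group here to shift the number beyond the scatter, towards a weaker effect (a number 18 percentage points higher from compound 3 to compound 4 (beyond the scatter); a number 22 percentage points higher from compound 2 to compound 4 (beyond the scatter); a number 22 percentage points higher from compound 1 to compound 4 (beyond the scatter)). The position therefore does respond to the choice of aryl group, although the three halogen-bearing groups stayed within the scatter of one another. Nothing available explains this shift. The compounds shown leave open whether unsubstituted phenyl, 4-methylphenyl or 4-hydroxyphenyl on that nitrogen would give a similar number.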